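The source may hold more compounds than are shown below. What is called first, only, known or untested is meant among the compounds shown, and "the series" means these compounds.

Measured in a functional assay on PC-3 cells (Homo sapiens) for antiproliferative activity, read by MTT assay, with a stated time of 24 h; a lower number here means a stronger inhibitor, a higher number a weaker inhibitor:
- compound 1 `CCn1c(C(=O)NCCO)ccc1C(CC)(CC)c1ccc(OCS(=O)(=O)c2ccccc2)c(C)c1`: 17700 nM
- compound 2 `CCn1c(C(=O)N[C@@H](C(=O)O)C(C)C)ccc1C(CC)(CC)c1ccc(OCS(=O)(=O)c2ccccc2)c(C)c1`: 3070 nM

Compound 2 has the lower of these two numbers, which makes it the stronger inhibitor of the pair. Compound 3 `CCn1c(C(=O)N[C@H](CC(=O)O)C(=O)O)ccc1C(CC)(CC)c1ccc(OCS(=O)(=O)c2ccccc2)c(C)c1` has not yet been measured. It has carboxymethyl in place of isopropyl on a saturated chain carbon bound to an amide-type nitrogen and a carbonyl carbon.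

For the measured compounds named here, one measured step bears on this change, since it also altered the group on that amide-type nitrogen: a 5.8-fold lower number from compound 1 to compound 2 (0.76 log units; beyond the scatter). This modest step does not test carboxymethyl itself. Compound 1 also lacks isopropyl and stands at 17700 nM, so a modest move to a higher number is expected in this assay.

The expected change is a 2.1-fold higher number from compound 2 to compound 3 (0.33 log units; beyond the scatter). For compound 3 the estimated value is 6500 nM, with an expected range from 2000 nM to 18000 nM.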

Compound 3, half-maximal inhibitory concentration: > 50000 nM
Compound 3 was reported as a limit (the forecaster's own chance of this, stated with the estimate: 5%); middle value at least 7.6-fold (0.88 log units) from the limit.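

In this assay the group on this saturated chain carbon proves able to swing the result strongly: carboxymethyl in place of isopropyl gives an at least 16-fold higher number from compound 2 to compound 3 (1.21 log units; beyond the scatter) and so removes the gain that compound 2 had shown. The step of a 5.8-fold lower number from compound 1 to compound 2 (0.76 log units; beyond the scatter) had pointed the other way, yet 1,2-dicarboxyethyl in place of 2-hydroxyethyl gives an at least 2.8-fold higher number from compound 1 to compound 3 (0.45 log units; beyond the scatter) and so places compound 3 behind compound 1 as well, which means that a substituted chain on this nitrogen does not help in every case. The reading for compound 3 is a limit and not a number, so both new steps give only a smallest size: the limit of > 50000 nM in this assay, at which 1 of the 3 values shown sits.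

From the compounds shown here alone, it stays open whether the loss follows from the added carboxylic acid or from the missing isopropyl. A carbamoylmethyl group or a plain methyl at this place would help to separate the two.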